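An Aromatic Ring Replaces Cyclobutyl on the Shared Core

The source may hold more compounds than are shown below. What is called first, only, known or untested is meant among the compounds shown, and "the series" means these compounds.

compound 1: `O=C(O)c1ccccc1-c1ccc(CCc2ncc(CC3CCC3)[nH]2)cc1`, 7.1 nM
compound 2: `N#Cc1ccccc1Cc1cnc(CCc2ccc(-c3ccccc3C(=O)O)cc2)[nH]1`, 642 nM
compound 3: `CC(C)(C)Cc1cnc(CCc2ccc(-c3ccccc3C(=O)O)cc2)[nH]1`, 6.3 nM

In an in vitro functional assay on cells for agonist activity at Bombesin receptor subtype-3 (Mus musculus), read by luminescence and calcium flux (on this read-out lower numbers stand for an effect already at smaller amounts and higher numbers for an effect only at larger amounts of compound), compound 1 gives 7.1 nM and stands second highest of the three numbers. Compound 3 is nearest to it, a 1.1-fold lower number from compound 1 to compound 3 (0.05 log units; within the scatter), and compound 2 is furthest, a 90-fold higher number from compound 1 to compound 2 (1.96 log units; beyond the scatter).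

Compound 4, `Cc1ccccc1Cc1cnc(CCc2ccc(-c3ccccc3C(=O)O)cc2)[nH]1`, has not yet been measured. It differs from compound 1 by 2-methylphenyl in place of cyclobutyl on a saturated chain carbon bound to an aromatic carbon.

Within the data shown here, two measured steps bear on this change. The step of a 90-fold higher number from compound 1 to compound 2 (1.96 log units; beyond the scatter) is the one case in which an aromatic ring entered at this place, and the number rose sharply; the step of a 1.1-fold lower number from compound 1 to compound 3 (0.05 log units; within the scatter), tert-butyl in place of cyclobutyl, stayed within the scatter. Among the measured compounds shown here, compound 4 carries 2-methylphenyl where compound 2 carries 2-cyanophenyl, and no measured pair separates those two groups, so the size of the effect of the methyl-bearing ring is unknown. Compound 4 is therefore expected to show a higher number than compound 1, with the step estimated at a 17-fold higher number from compound 1 to compound 4 (1.23 log units; beyond the scatter), likely large but uncertain in extent. Compound 4 is estimated at 120 nM, in a range from 15 nM to 900 nM.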

Compound 4, half-maximal effective concentration: 9.3 nM
Estimate against measurement, compound 4: 13-fold (1.11 log units) above, outside the stated range (below it).
By their numbers in this assay, from the lowest: compounds 3, 1 and 4 (each within the scatter of the next); then compound 2.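

In this assay, an aromatic ring on a saturated chain carbon bound to an aromatic carbon does not by itself bring the large rise that compound 2 suggested: 2-methylphenyl in place of cyclobutyl gives a 1.3-fold higher number from compound 1 to compound 4 (0.12 log units; within the scatter), and 2-methylphenyl in place of tert-butyl gives a 1.5-fold higher number from compound 3 to compound 4 (0.17 log units; within the scatter). The large difference goes instead with the single change on the ring, methyl in place of cyano on an aromatic carbon, which gives a 69-fold lower number from compound 2 to compound 4 (1.84 log units; beyond the scatter), so that among these four compounds only compound 2 stands apart, while cyclobutyl, tert-butyl and 2-methylphenyl are not told apart by this read-out. Nothing available explains why the cyano-bearing ring and the methyl-bearing ring differ so widely.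

The compounds shown leave open whether a plain phenyl, or a ring carrying chlorine, methoxy or an amine in place of the methyl, would stay with compound 4 or move towards compound 2. They also leave open whether the tolerance seen here holds for a longer chain carrying the 2-methylphenyl ring, or for a pyridine ring in its place.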